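This account rests on a few compounds, and the source may have more. Where it says the series, first, only, none or still open, it means among the compounds named here.

The measured compounds:

Compound 1, `COc1ccccc1NC(=O)CN(c1cc(Cl)ccc1OC)S(=O)(=O)c1ccccc1`, giving 15500 nM in a functional assay on SH-SY5Y cells (Homo sapiens), read by MTT assay, with a stated time of 24 h; a lower number here means that less compound is needed, a higher number that more compound is needed for the effect.
Compound 2, `COc1ccc(NC(=O)CN(c2cc(Cl)ccc2OC)S(=O)(=O)c2ccccc2)cc1OC`, giving > 20000 nM in this assay, which is a limit of the assay rather than a number.
Compound 3, `COc1cccc(NC(=O)CN(c2cc(Cl)ccc2OC)S(=O)(=O)c2ccccc2)c1`, giving 17600 nM in this assay.

Compound 3 holds the highest of the two numbers, but its nearest neighbour is compound 1 with a 1.1-fold higher number from compound 1 to compound 3 (0.06 log units; within the scatter), so the two are not separated. For the measured compounds named here, compound 2 sits at a limit, (the limit of > 20000 nM in this assay, at which 1 of the 3 values shown sits), and the steps of an at least 1.2-fold higher number from compound 1 to compound 2 (0.11 log units; that floor lies within the scatter) and an at least 1.1-fold lower number from compound 2 to compound 3 (0.05 log units; that floor lies within the scatter) show only that its number is not lower than those of the others. Compound 4, `CCn1ccc2cc(NC(=O)CN(c3cc(Cl)ccc3OC)S(=O)(=O)c3ccccc3)ccc21`, differs from compound 3 by 1-ethyl-1H-indol-5-yl in place of 3-methoxyphenyl on an amide-type nitrogen. Going by the values given here, the measured steps all swap one methoxyphenyl for another on the amide-type nitrogen, and none of them moves beyond the scatter; no step involves an indole. From these alone no step beyond the scatter is expected for compound 4 in this assay, so a 1.2-fold lower number from compound 3 to compound 4 (0.07 log units; within the scatter) is the expected step. The estimated value of compound 4 is 15000 nM, within 5000 nM to 40000 nM.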

Compound 4, half-maximal effective concentration: 2220 nM
For compound 4 the middle estimate is 6.8-fold (0.83 log units) above the measured one, and the stated range ends above it.
By their numbers in this assay, from the lowest: compound 4; then compounds 1 and 3 (each within the scatter of the next). At a limit, above all of these: compound 2.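

In this assay, the place on the amide-type nitrogen turns out to respond beyond the scatter, which none of the swaps among methoxyphenyl groups had shown: 1-ethyl-1H-indol-5-yl in place of 3-methoxyphenyl gives a 7.9-fold lower number from compound 3 to compound 4 (0.90 log units; beyond the scatter), and in place of 2-methoxyphenyl it gives a 7.0-fold lower number from compound 1 to compound 4 (0.84 log units; beyond the scatter). Replacing 3,4-dimethoxyphenyl in the same place gives an at least 9.0-fold lower number from compound 2 to compound 4 (0.95 log units; beyond the scatter), which is only a floor on the size of the step. Compound 2 stands at a limit of the assay, not at a number: the limit of > 20000 nM in this assay, at which 1 of the 4 values shown sits.

From the compounds shown here alone, it remains open whether the lower number goes with the indole ring or with its ethyl group, and an indole carrying a hydrogen or a propyl chain in place of the ethyl would bear on that. Also open, going by these compounds, is how an amine or a carboxylic acid on the indole would read in this assay.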